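The source may report more compounds than this note shows. Statements on the series, on what has been measured and on what is new or still open speak of the compounds shown alone.

Measured compounds:
Compound 1 `COc1ccc(S(=O)(=O)N2CCc3cccc(NC(=O)Oc4ccccc4)c32)cc1` gives > 10000 nM in a functional assay on MKN-45 cells (Homo sapiens) for cytotoxicity; on this read-out lower numbers stand for stronger inhibition and higher numbers for weaker inhibition; this is a limit of the assay, not a number.
Compound 2 `COc1ccc(S(=O)(=O)N2CCc3cccc(NC(=O)C(C)(C)C)c32)cc1` gives 289 nM in this assay.
Compound 3 `COc1ccc(S(=O)(=O)N2CCc3cccc(N)c32)cc1` gives 1200 nM in this assay.

Compound 3 stands highest of the two numbers shown; the only other number lies close to it, and the step between them is a 4.2-fold higher number from compound 2 to compound 3 (0.62 log units; beyond the scatter). The third value is a limit.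

Compound 4 `COc1ccc(S(=O)(=O)N2CCc3cccc(NC(=O)c4ccc(F)cc4)c32)cc1` differs from compound 3 by (4-fluorophenyl)carbonyl in place of hydrogen on a nitrogen on an aromatic ring. Among the compounds with values here, two measured steps bear on acylation of this nitrogen. The step of a 4.2-fold higher number from compound 2 to compound 3 (0.62 log units; beyond the scatter), read in reverse, shows that a (tert-butyl)carbonyl on the nitrogen lowers the number by a modest margin. The step of an at least 8.3-fold lower number from compound 1 to compound 3 (0.92 log units; beyond the scatter) shows that a phenoxycarbonyl on the same nitrogen raises it, with compound 1 sitting at the limit of > 10000 nM in this assay, at which 1 of the 3 values shown sits. The (4-fluorophenyl)carbonyl is a carbonyl bearing carbon, like the (tert-butyl)carbonyl, rather than a phenoxycarbonyl, so a modest lowering is expected, estimated as a 3.0-fold lower number from compound 3 to compound 4 (0.48 log units; beyond the scatter). For compound 4 the expected value in this assay is 400 nM, with a range of 100 nM to 2000 nM.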

Compound 4, half-maximal inhibitory concentration: 45 nM
Compound 4: middle estimate off by 8.9-fold (0.95 log units), on the high side; the whole stated range lies above it.
By their numbers in this assay, from the lowest: compound 4; then compound 2; then compound 3. At a limit, above all of these: compound 1.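

In this assay, the nitrogen on an aromatic ring tolerates far more than the modest gain seen with the (tert-butyl)carbonyl: the (4-fluorophenyl)carbonyl gives a 27-fold lower number from compound 3 to compound 4 (1.43 log units; beyond the scatter). The group on the carbonyl carbon also counts, not the acylation alone, as 4-fluorophenyl in place of tert-butyl gives a 6.4-fold lower number from compound 2 to compound 4 (0.81 log units; beyond the scatter). With 4-fluorophenyl in place of phenoxy, an at least 220-fold lower number from compound 1 to compound 4 (2.34 log units; beyond the scatter) is a bound and not a measured size, and compound 1 remains at a limit of the assay: the limit of > 10000 nM in this assay, at which 1 of the 4 values shown sits.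

The compounds shown do not separate the fluorine from the phenyl ring within the (4-fluorophenyl)carbonyl. They also leave open whether a pyridine ring, an amine or a carboxylic acid on the carbonyl carbon would keep this level.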